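Swapping a bromine-bearing ring for a catechol ring

A few compounds are considered here, and "the series" means these few. Any claim that something is new, unique, unknown or untested is made for them only; others in the source may bear on it.

Compound 1 `COc1cccc(/C=C2\CCC/C(=C\c3ccc(Br)cc3)C2=O)c1OC` is the starting point. In an ADME assay on NHDF cells (Homo sapiens) for cytotoxicity, read by MTT assay, with a stated time of 72 h (on this read-out lower numbers stand for stronger inhibition and higher numbers for weaker inhibition), compound 1 gives 21400 nM, the highest of the three numbers measured. Compound 2 `COc1ccc(/C=C2\CCC/C(=C\c3cccc(OC)c3OC)C2=O)cc1OC` gives 14900 nM, a value that sits within the scatter of compound 1. Compound 3 `COc1cccc(/C=C2\CCC/C(=C\c3cc(OC)c(OC)c(OC)c3)C2=O)c1OC` gives 7900 nM, and its gap to compound 1 lies beyond the scatter. Among the compounds with values here, the only single-point step available, a 1.9-fold lower number from compound 2 to compound 3 (0.28 log units; within the scatter), shows that adding one methoxy group moved the number little.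

Compound 4 `COc1cccc(/C=C2\CCC/C(=C\c3ccc(O)c(O)c3)C2=O)c1OC` is not yet measured. It differs from compound 1 by 3,4-dihydroxyphenyl in place of 4-bromophenyl on a double-bonded chain carbon bound to a double-bonded ring carbon. Within the data shown here, no measured step exchanges a bromine-bearing ring for a hydroxyl-bearing one, so the change is unlike any step seen; the one step available, a 1.9-fold lower number from compound 2 to compound 3 (0.28 log units; within the scatter), stayed within the scatter when a ring substituent was altered. On that basis no step beyond the scatter is expected, and the estimate for compound 4 is a 1.4-fold lower number from compound 1 to compound 4 (0.15 log units; within the scatter). Compound 4 is therefore expected to give about 15000 nM, within a range from 5000 nM to 45000 nM.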

Compound 4, half-maximal inhibitory concentration: 17900 nM
Beside the measured number, compound 4's estimate is 1.2-fold (0.08 log units) below it, and the stated range covers the measured number.
By their numbers in this assay, from the lowest: compounds 3, 2, 4 and 1 (each within the scatter of the next, the first and the last beyond it).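

On a double-bonded chain carbon bound to a double-bonded ring carbon, 3,4-dihydroxyphenyl can take the place of 4-bromophenyl while this assay stays within the usual scatter, with a 1.2-fold lower number from compound 1 to compound 4 (0.08 log units; within the scatter). This exchange replaces a whole ring substituent pattern, not just one group: a ring that carries hydrogen-bond donors and acceptors stands where a ring with neither stood, so this position tolerates a larger swap than the earlier step showed. No supporting data bear on this result, so it stands without an explanation.

On these data alone, it remains open whether a ring carrying an amine or a carboxylic acid at this position would also stay within the scatter. As far as these compounds go, what each hydroxyl group of 3,4-dihydroxyphenyl contributes on its own also remains open.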